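Swapping Cyclobutyl for Methylsulfanyl on the Shared Core

This account rests on a few compounds, and the source may have more. Where it says the series, first, only, none or still open, it means among the compounds named here.

Of the compounds shown here, two have been measured in a functional assay for inhibition of sodium/hydrogen exchanger (Oryctolagus cuniculus); on this read-out higher numbers stand for weaker inhibition and lower numbers for stronger inhibition. Compound 1 `CCc1cc(C)c(C(=O)N=C(N)N)cc1S(C)(=O)=O` gives 4.8 nM in this assay. Compound 2 `Cc1cc(C2CCC2)c(S(C)(=O)=O)cc1C(=O)N=C(N)N` gives 8.2 nM in this assay. Compound 2 stands highest of the two numbers, but its nearest neighbour is compound 1, and the step of a 1.7-fold higher number from compound 1 to compound 2 (0.23 log units; within the scatter) lies within the scatter, so the two compounds cannot be told apart on these numbers.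

Compound 3 `CSc1cc(C)c(C(=O)N=C(N)N)cc1S(C)(=O)=O` has not yet been measured. It differs from compound 2 by methylsulfanyl in place of cyclobutyl on an aromatic carbon.

For the measured compounds named here, no measured step exchanges a methylsulfanyl group, so the only step that bears on this one at all is a 1.7-fold higher number from compound 1 to compound 2 (0.23 log units; within the scatter), which exchanged one carbon group for another on an aromatic carbon and stayed within the scatter. On that slim basis the expectation for compound 3 is a step of a 1.0-fold lower number from compound 2 to compound 3 (0.01 log units; within the scatter) in this assay, no larger than the scatter in either direction. Compound 3 is therefore estimated at 8 nM in this assay, with a range from 3 nM to 24 nM.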

Compound 3, half-maximal inhibitory concentration: 6 nM
Compound 3: middle estimate off by 1.3-fold (0.12 log units), on the high side; measured number inside the range.
By their numbers in this assay, from the lowest: compounds 1, 3 and 2 (each within the scatter of the next).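

The aromatic carbon ortho to a methylsulfonyl group has now carried a sulfur-linked group as well as carbon groups, and in this assay methylsulfanyl in place of cyclobutyl gives one small step (a 1.4-fold lower number from compound 2 to compound 3 (0.14 log units; within the scatter)), while methylsulfanyl in place of ethyl gives another (a 1.3-fold higher number from compound 1 to compound 3 (0.10 log units; within the scatter)). Both steps lie within the scatter, so ethyl, cyclobutyl and methylsulfanyl cannot be told apart at this position on the shared core, even though methylsulfanyl, unlike cyclobutyl, has no ring and brings a hydrogen-bond acceptor. Nothing available explains why these three groups read alike.

The compounds shown leave open whether this position would still read the same with an amine, a carboxylic acid or a longer chain such as hexyl, any of which would put something quite different on this carbon. They also leave open how a methoxy group, the oxygen counterpart of methylsulfanyl, would read here, and whether the same exchanges would read alike at any other position on the core.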